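A Pyridyl-to-Methylphenyl Swap on a Shared Core

This account rests on a few compounds, and the source may have more. Where it says the series, first, only, none or still open, it means among the compounds named here.

Going by the values given here, compound 2 `CS(=O)(=O)c1ccc(-c2cnc3[nH]cc(-c4nnc(-c5ccccn5)o4)c(=O)c3c2)cc1` holds the higher of the two numbers so far in a functional assay on HCT-116 cells (Homo sapiens) for positive allosteric modulation, read by MTT assay, with stated times of 24 h and 48 h, tested at 2.5 uM (on this read-out lower numbers stand for less inhibition of growth and higher numbers for more inhibition of growth at the one concentration tested), where compound 2 gives 34.3%. Among the compounds with values here, its only neighbour, compound 1 `N#Cc1ccc(-c2cnc3[nH]cc(-c4nnc(-c5ccc(F)cc5)o4)c(=O)c3c2)cc1`, gives 25.6% in this assay, a gap within the scatter, so the two cannot be told apart. Compound 3 `Cc1cccc(-c2nnc(-c3c[nH]c4ncc(-c5ccc(S(C)(=O)=O)cc5)cc4c3=O)o2)c1` is not yet measured; it differs from compound 2 in 3-methylphenyl in place of pyridin-2-yl on an aromatic carbon. Within the data shown here, no measured pair differs in just one place, so nothing yet shows what such a swap does. Compound 3 is expected to show a step of a number 1.3 percentage points lower from compound 2 to compound 3 (within the scatter), nothing beyond the scatter. The estimated value for compound 3 in this assay is 33%, with a range from 15% to 52%.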

Compound 3, percent growth inhibition at one concentration: 50.8%
For compound 3 the middle estimate is 17.8 percentage points below the measured one; the measured number falls inside the stated range.
By their numbers in this assay, from the lowest: compounds 1 and 2 (each within the scatter of the next); then compound 3.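

Going by these compounds alone, this is the first pair that differs in one place, and it shows that the group on this carbon of the five-membered ring can change the result: in this assay, 3-methylphenyl in place of pyridin-2-yl gives a number 16.5 percentage points higher from compound 2 to compound 3 (beyond the scatter), a modest step. The swap takes out the ring nitrogen and brings in a methyl group, and this single pair cannot separate those two changes. Nothing available explains the step. Still open, going by these compounds, is whether plain phenyl would give a similar number, and what a methoxy group or an amine in place of the methyl would do.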